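The source may hold more compounds than are shown below. What is called first, only, known or untested is meant among the compounds shown, and "the series" means these compounds.

Compound 1 `CCOC(=O)C1=Cc2ccccc2OC1(OCc1cn(-c2ccc(F)cc2)nn1)C(F)(F)F` gives 8400 nM in a functional assay on HeLa cells (Homo sapiens) for inhibition, read by MTT assay, with a stated time of 24 h; on this read-out lower numbers stand for stronger inhibition and higher numbers for weaker inhibition.
Compound 2 `CCOC(=O)C1=Cc2ccccc2OC1(OCc1cn(CC(=O)NC2CCCCC2)nn1)C(F)(F)F` gives 11400 nM in this assay.

Compound 2 shows the highest of the two numbers, though its step from compound 1 is small: a 1.4-fold higher number from compound 1 to compound 2 (0.13 log units; within the scatter).

Compound 3 `CCOC(=O)C1=Cc2ccccc2OC1(OCc1cn(CC(=O)Nc2ccc(C)cc2)nn1)C(F)(F)F` differs from compound 2 in one place: 4-methylphenyl in place of cyclohexyl on an amide-type nitrogen. For the measured compounds named here, no measured step touches this position. Going by the values given here, the only step recorded, from compound 1 to compound 2, concerns a different position, the substituent on the aromatic nitrogen, and stays within the scatter. It therefore gives no direction for the present change, and nothing in the two measured compounds points to a step beyond the scatter for compound 3 in this assay.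

Compound 3 is therefore expected to sit close to compound 2, at about 10000 nM, with a range from 4000 nM to 25000 nM. The expected step from compound 2 to compound 3 is a 1.1-fold lower number from compound 2 to compound 3 (0.06 log units; within the scatter).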

Compound 3, half-maximal inhibitory concentration: 67400 nM
Compound 3: the middle estimate sits 6.7-fold (0.83 log units) below what was measured; the measured number lies above the stated range.
By their numbers in this assay, from the lowest: compounds 1 and 2 (each within the scatter of the next); then compound 3.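

In this assay, the amide-type nitrogen proves to be a place where the number can move beyond the scatter: 4-methylphenyl in place of cyclohexyl gives a 5.9-fold higher number from compound 2 to compound 3 (0.77 log units; beyond the scatter). Replacing 4-fluorophenyl on the aromatic nitrogen with ((4-methylphenyl)carbamoyl)methyl gives an 8.0-fold higher number from compound 1 to compound 3 (0.90 log units; beyond the scatter), whereas the (cyclohexylcarbamoyl)methyl of compound 2 stayed within the scatter of compound 1, so the group on the amide-type nitrogen decides the outcome among these compounds. Nothing available bears on the origin of this step.

From the compounds shown here alone, what an unsubstituted phenyl or a benzyl on the same nitrogen would give remains open. Going by these compounds, it also remains open whether the higher number goes with the aromatic ring itself or with its methyl group.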